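Moving from a Carboxylic Acid to an Acyl Sulfonamide

The compounds below may be only part of what the source reports. "The series", "measured", "known", "first", "only" and "open" are said of these compounds alone.

Compound 1 `CC(C)(Oc1ccc([C@H]2CC[C@]3(CC2)OOC2(O3)C3CC4CC(C3)CC2C4)cc1)C(=O)O` gives < 7 mL.min-1.g-1 in an ADME assay on microsomes from liver (Homo sapiens) for metabolic stability, using NADPH, with a stated time of 60 min, in the presence of a further agent that is not named here (a lower number here means slower removal, a higher number faster removal of the compound), and this is a limit of the assay rather than a number.
Compound 2 `O=C(O)COc1ccc([C@H]2CC[C@]3(CC2)OOC2(O3)C3CC4CC2CC(C3)C4O)cc1` gives < 7 mL.min-1.g-1 in this assay, again a limit of the assay.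
Compound 3 `O=C(O)c1cc([C@H]2CC[C@]3(CC2)OOC2(O3)C3CC4CC(C3)CC2C4)ccc1O` gives 108 mL.min-1.g-1 in this assay.

Compound 1 therefore stands at the limit of < 7 mL.min-1.g-1 in this assay, at which 2 of the 3 values shown sit. Its clearance is known only to lie under that limit, so no number for it can be placed against the value of compound 3.

Compound 4 `CS(=O)(=O)NC(=O)COc1ccc([C@H]2CC[C@]3(CC2)OOC2(O3)C3CC4CC(C3)CC2C4)cc1` has not yet been measured. It differs from compound 1 in one place: ((methylsulfonyl)carbamoyl)methyl in place of 1-carboxy-1-methylethyl on an oxygen on an aromatic ring. The shared core and the oxygen on the aromatic ring stay as they are.

Going by the values given here, no step between two measured compounds is recorded here that would show how such a change moves clearance, and the starting point is itself a limit. Compound 4 is expected to remain in the slow-removal region, close to compound 1, with the step from compound 1 to compound 4 estimated at an at least 1.4-fold higher number from compound 1 to compound 4 (0.15 log units; that floor lies within the scatter). For compound 4 the estimated clearance in this assay is 10 mL.min-1.g-1, with a likely range from 5 mL.min-1.g-1 to 30 mL.min-1.g-1, and there is a fair chance the assay again reports only a limit.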

Compound 4, intrinsic clearance in microsomes: < 7 mL.min-1.g-1
Compound 4 ended at the assay's limit; the forecaster's own chance of this, stated with the estimate: 40%; middle value at least 1.4-fold (0.15 log units) away from the limit.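

In this assay compound 4 gives < 7 mL.min-1.g-1, a limit of the assay and not a number. Going by these compounds alone, compound 1 also sits at a limit, so no step between compound 1 and compound 4 can be read: the limit of < 7 mL.min-1.g-1 in this assay, at which 3 of the 4 values shown sit. From the compounds shown here alone, how much ((methylsulfonyl)carbamoyl)methyl in place of 1-carboxy-1-methylethyl changes clearance, if at all, stays open.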